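Chloro in place of hydrogen at the weak end

This account rests on a few compounds, and the source may have more. Where it says the series, first, only, none or still open, it means among the compounds named here.

In a functional assay on K562 cells (Homo sapiens) for antiproliferative activity, read by MTT assay, with a stated time of 48 h (on this read-out higher numbers stand for weaker inhibition of growth and lower numbers for stronger inhibition of growth), compound 2 (`COc1ccc(Cn2cnc3c(Cl)ncnc32)cc1OC`) gives > 50000 nM, which is a limit of the assay. Compound 3 (`COc1cc(Cn2cnc3c(Cl)ncnc32)cc(OC)c1OC`) gives > 50000 nM, also a limit. Among the compounds with values here, the only measured step is a step that the two limits leave unreadable from compound 2 to compound 3, so it sets no size for the change ahead. Compound 2 therefore stands at the limit of > 50000 nM in this assay, at which 2 of the 3 values shown sit. Compound 1 (`COc1ccc(N(C)c2nc(Cl)nc3c2ncn3Cc2ccc(OC)c(OC)c2)cc1`) alone gives a number, 27000 nM, and it also carries this chloro group. Compound 4 (`COc1ccc(Cn2cnc3c(Cl)nc(Cl)nc32)cc1OC`) differs from compound 2 by chloro in place of hydrogen on an aromatic carbon. On the strength of 27000 nM for compound 1, at most a small move toward stronger inhibition of growth is expected in this assay. The expected move is an at least 1.2-fold lower number from compound 2 to compound 4 (0.09 log units; that floor lies within the scatter). For compound 4 the estimate is 40000 nM, with an expected range of 15000 nM to 60000 nM.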

Compound 4, concentration for 50% growth inhibition: 7000 nM
Beside the measured number, compound 4's estimate is 5.7-fold (0.76 log units) above it; the measured number lies below the stated range.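

In this assay, within the data shown here, chloro in place of hydrogen on the aromatic carbon between two ring nitrogen atoms brings an at least 7.1-fold lower number from compound 2 to compound 4 (0.85 log units; beyond the scatter) and is the first readable effect. That size is only a floor, since compound 2 stands at a limit: the limit of > 50000 nM in this assay, at which 2 of the 4 values shown sit. With that chloro kept, chloro in place of (4-methoxyphenyl)(methyl)amino on an aromatic carbon brings a 3.9-fold lower number from compound 1 to compound 4 (0.59 log units; beyond the scatter) and shows that the amino group is not needed for a measurable number. Open: whether fluoro, bromo or a simple amine on the carbon between two ring nitrogen atoms would match chloro.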